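Ring size at the amine substituent and maximal response

The compounds below may be only part of what the source reports. "The series", "measured", "known", "first", "only" and "open" are said of these compounds alone.

Measured compounds:
Compound 1, `CC(C)(C)OC(=O)N1CCC(O[C@H]2CC[C@H](Oc3cnc(S(C)(=O)=O)cn3)CC2)CC1`, in a functional assay on isolated protein for agonist activity at Glucose-dependent insulinotropic receptor (Rattus norvegicus), read by HTRF and cAMP accumulation (on this read-out higher numbers stand for larger maximal responses and lower numbers for smaller maximal responses), compound 1 gives 110%.
Compound 2, `CS(=O)(=O)c1cnc(O[C@H]2CC[C@H](OC3CCN(CC4(C(F)(F)F)CCC4)CC3)CC2)cn1`, in this assay compound 2 gives 99%.

Compound 2 stands lowest of the two numbers shown; its nearest neighbour is compound 1, and the step of a number 11 percentage points lower from compound 1 to compound 2 (beyond the scatter) separates them. That step exchanged a tert-butoxycarbonyl for a (1-(trifluoromethyl)cyclobutyl)methyl group on the amine nitrogen in a ring.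

Compound 3, `CS(=O)(=O)c1cnc(O[C@H]2CC[C@H](OC3CCN(CC4(C(F)(F)F)CCCC4)CC3)CC2)cn1`, has not yet been measured in this assay. It differs from compound 2 in one place: a group of 9 heavy atoms (6 carbon, 3 fluorine; one five-membered non-aromatic ring of carbon only) in place of a group of 8 heavy atoms (5 carbon, 3 fluorine; one four-membered non-aromatic ring of carbon only), on a saturated chain carbon bound to an amine nitrogen in a ring. For the measured compounds named here, the only measured step does not concern this change, since it replaced a whole different group rather than enlarging the ring. Going by the values given here, no step on record bears on this change. On that basis the expected step is no change at the digits printed from compound 2 to compound 3 (within the scatter).

For compound 3 a value of 99% is estimated in this assay, with a range from 85% to 112%.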

Compound 3, largest response reached (Emax), in percent of the reference or control that the assay uses: 88%
Beside the measured number, compound 3's estimate is 11 percentage points above it; low and high end bracket the measured number.
By their numbers in this assay, from the lowest: compound 3; then compound 2; then compound 1.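

In this assay, enlarging the carbon ring from 1-(trifluoromethyl)cyclobutyl to its five-membered counterpart, on a saturated chain carbon bound to an amine nitrogen in a ring, gives a number 11 percentage points lower from compound 2 to compound 3 (beyond the scatter). Ring size alone at this position therefore moves the maximal response by more than the usual scatter, and the full exchange from the tert-butoxycarbonyl group gives a number 22 percentage points lower from compound 1 to compound 3 (beyond the scatter). Nothing available speaks to the cause of this drop.

Going by these compounds, whether the response would keep falling with a still larger ring, such as a 1-(trifluoromethyl)cyclohexyl group, remains open. So does the part played by the trifluoromethyl group itself, which a methyl group or a single hydrogen in its place on the same ring would help to separate from ring size.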